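A few compounds are considered here, and "the series" means these few. Any claim that something is new, unique, unknown or untested is made for them only; others in the source may bear on it.

The measured compounds:

Compound 1 `O=C(NCCCCc1ccccc1)n1c(=O)oc2ccccc21` gives 64 nM in an assay on HEK293 cells for inhibition of acid ceramidase (Homo sapiens), with a stated time of 10 min; on this read-out lower numbers stand for stronger inhibition and higher numbers for weaker inhibition.
Compound 2 `COc1ccc(CCCCNC(=O)n2c(=O)oc3ccccc32)cc1` gives 63 nM in this assay.
Compound 3 `O=C(NCCCCCCc1ccccc1)n1c(=O)oc2ccccc21` gives 51 nM in this assay.

Compound 3 has the lowest of these three numbers, but it is not set apart: the steps of a 1.3-fold lower number from compound 1 to compound 3 (0.10 log units; within the scatter) and a 1.2-fold lower number from compound 2 to compound 3 (0.09 log units; within the scatter) both lie within the scatter, so the three compounds stand together on this read-out.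

Compound 4 `O=C(NCCCCc1cccs1)n1c(=O)oc2ccccc21` has not yet been measured. It differs from compound 3 by thiophen-2-yl in place of phenethyl on a saturated chain carbon, four bonds along the chain from an amide-type nitrogen. The measured steps that bear on this change are those that also alter the group at this position on the chain: a 1.0-fold lower number from compound 1 to compound 2 (0.01 log units; within the scatter), a 1.3-fold lower number from compound 1 to compound 3 (0.10 log units; within the scatter) and a 1.2-fold lower number from compound 2 to compound 3 (0.09 log units; within the scatter). None of them moved the number beyond the scatter, whether the group at the end of the chain was phenyl, 4-methoxyphenyl or phenethyl. Nothing in the measured set speaks to a five-membered ring with a hetero atom at this place, so the expectation rests on the steadiness seen so far. The expected step is therefore small, in no particular direction, a 1.2-fold higher number from compound 3 to compound 4 (0.07 log units; within the scatter). Compound 4 is expected to give 60 nM, within a range from 25 nM to 150 nM.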

Compound 4, half-maximal inhibitory concentration: 37 nM
Beside the measured number, compound 4's estimate is 1.6-fold (0.21 log units) above it, within the range that was stated.
By their numbers in this assay, from the lowest: compounds 4, 3, 2 and 1 (each within the scatter of the next).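

In this assay the end of the chain now accepts a five-membered aromatic ring with a sulfur atom, and the number stays within the scatter of all three earlier compounds: the steps are a 1.4-fold lower number from compound 3 to compound 4 (0.14 log units; within the scatter) and a 1.7-fold lower number from compound 2 to compound 4 (0.23 log units; within the scatter) and a 1.7-fold lower number from compound 1 to compound 4 (0.24 log units; within the scatter) and none of them stands out. The earlier compounds shown here carried only six-membered aromatic rings of carbon at this place, on a saturated chain carbon, four bonds along the chain from an amide-type nitrogen, so the flat response now extends to a ring with a hetero atom, one that also has fewer heavy atoms than the phenethyl group it replaces in compound 3. The data shown offer nothing that explains why these four compounds stand so close together.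

As far as these compounds go, what remains open is whether this steadiness holds for an end group of another kind, such as an amine or a carboxylic acid in place of the aromatic ring. Also open is whether any ring is needed at all, since every compound shown ends in one and a plain alkyl chain does not appear among them.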